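This account rests on a few compounds, and the source may have more. Where it says the series, first, only, none or still open, it means among the compounds named here.

Values in a functional assay on OVCAR-3 cells (Homo sapiens) for inhibition, read by sulforhodamine B assay, with a stated time of 48 h; on this read-out lower numbers stand for higher toxicity in this test and higher numbers for lower toxicity in this test:

compound 1 `COc1cc(-c2cc(/C=C/C(=O)c3ccc(N)cc3)[nH]n2)cc(OC)c1OC`: 7260 nM
compound 2 `COc1ccc(-c2cc(/C=C/C(=O)c3ccc(OC)c(OC)c3)[nH]n2)cc1`: 5150 nM
compound 3 `COc1cc(-c2cc(/C=C/C(=O)c3ccc(Cl)c(Cl)c3)[nH]n2)cc(OC)c1OC`: a limit of the assay, > 100000 nM

Compound 1 stands at the highest of the two numbers; compound 2 gives a number lower by a margin that lies within the scatter, so no order between the two can be claimed, and the two structures differ in more than one place anyway. Compound 3 reaches only (the limit of > 100000 nM in this assay, at which 1 of the 3 values shown sits). Going by the values given here, the single step measured in one place, an at least 13-fold higher number from compound 1 to compound 3 (1.13 log units; beyond the scatter), concerns the aryl on the carbonyl carbon and leaves the aryl on the shared core untouched.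

Compound 4 `COc1ccc(-c2cc(/C=C/C(=O)c3ccc(N)cc3)[nH]n2)cc1OC` differs from compound 1 on that other aryl: hydrogen in place of methoxy on an aromatic carbon. Among the compounds with values here, no measured step bears on this position, so the size of the step has no anchor. With the 4-aminophenyl on the carbonyl carbon kept as in compound 1, no step beyond the scatter is expected in this assay, in either direction. For compound 4 the expected value is 8000 nM (range 3000 nM to 25000 nM), which means an expected step of a 1.1-fold higher number from compound 1 to compound 4 (0.04 log units; within the scatter).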

Compound 4, concentration lethal to 50% of the cells: 9140 nM
Beside the measured number, compound 4's estimate is 1.1-fold (0.06 log units) below it; measured number inside the range.
By their numbers in this assay, from the lowest: compounds 2, 1 and 4 (each within the scatter of the next). At a limit, above all of these: compound 3.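

Hydrogen in place of methoxy on this aromatic carbon, with the 4-aminophenyl on the carbonyl carbon kept, gives in this assay a 1.3-fold higher number from compound 1 to compound 4 (0.10 log units; within the scatter). Going by these compounds alone, this is the first measured step on the aryl of the shared core, and the methoxy at this place can be exchanged for hydrogen without a change that can be read, whereas the earlier step on the aryl on the carbonyl carbon, an at least 13-fold higher number from compound 1 to compound 3 (1.13 log units; beyond the scatter), lies beyond the scatter. Nothing measured in this set gives a reason for the size of the new step, and the reading rests on one pair of compounds.

Within the data shown here, whether the same exchange would stay within the scatter with 3,4-dichlorophenyl on the carbonyl carbon remains open, since the only compound with that group carries the full set of methoxy groups and stands at a limit of the assay. Also open, going by these compounds, is what a hydroxy group, a fluorine atom or an ethoxy group would give on this aromatic carbon, and whether the methoxy groups that remain in compound 4 can be exchanged in the same way.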